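The source may hold more compounds than are shown below. What is called first, only, known or untested is meant among the compounds shown, and "the series" means these compounds.

Three compounds share one core and differ only in the aryl group attached to it. Compound 1 `COc1cc(-n2cnc3ccc(-c4cccc(F)c4)cc32)cc(OC)c1OC` gives 2350 nM in a functional assay on MCF7 cells (Homo sapiens) for antiproliferative activity, read by MTT assay, with a stated time of 72 h; on this read-out lower numbers stand for stronger inhibition and higher numbers for weaker inhibition. Compound 2 `COc1cc(-n2cnc3ccc(-c4ccc(Cl)cc4)cc32)cc(OC)c1OC` gives 1320 nM in this assay, and compound 3 `COc1cccc(-c2ccc3ncn(-c4cc(OC)c(OC)c(OC)c4)c3c2)c1` gives 1610 nM. Compound 1 holds the highest number of the three, but its steps to both neighbours are small: a 1.8-fold lower number from compound 1 to compound 2 (0.25 log units; within the scatter) and a 1.5-fold lower number from compound 1 to compound 3 (0.16 log units; within the scatter), so these three compounds cannot be told apart on this read-out.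

Compound 4 `COc1cc(-n2cnc3ccc(-c4cccc([N+](=O)[O-])c4)cc32)cc(OC)c1OC` has not yet been measured. Its change from compound 1 is nitro in place of fluoro on an aromatic carbon. Among the compounds with values here, the step that bears most on it is the one from compound 1 to compound 3, where the same aromatic carbon carries a methoxy instead of the fluoro and the number moved only within the scatter; the step from compound 1 to compound 2 also stayed within the scatter. Compound 4 is therefore expected to show a step of a 1.2-fold lower number from compound 1 to compound 4 (0.09 log units; within the scatter), none beyond the scatter, with an estimated value of 1900 nM and a range from 800 nM to 4500 nM.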

Compound 4, half-maximal inhibitory concentration: 4560 nM
Beside the measured number, compound 4's estimate is 2.4-fold (0.38 log units) below it; measured number above the stated range.
By their numbers in this assay, from the lowest: compounds 2, 3, 1 and 4 (each within the scatter of the next, the first and the last beyond it).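

In this assay the nitro compound gives the first differences beyond the scatter, with a 2.8-fold higher number from compound 3 to compound 4 (0.45 log units; beyond the scatter) when nitro replaces methoxy and a 3.5-fold higher number from compound 2 to compound 4 (0.54 log units; beyond the scatter) when 3-nitrophenyl replaces 4-chlorophenyl. Against the fluoro compound the change stays inside the scatter, at a 1.9-fold higher number from compound 1 to compound 4 (0.29 log units; within the scatter), so fluoro and nitro cannot be told apart on this read-out. The group on this aromatic carbon can therefore shift the number, but the shifts seen are modest and run only towards weaker inhibition.

Nothing available explains why nitro and methoxy differ. From the compounds shown here alone, whether an amine or a carboxylic acid on this carbon would bring the number clearly lower than any seen so far remains open.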